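Methyl in place of hydrogen on the phenyl ring of compound 3

The source may report more compounds than this note shows. Statements on the series, on what has been measured and on what is new or still open speak of the compounds shown alone.

Of the compounds shown here, three sharing one core have been measured in a functional assay on DU-145 cells (Homo sapiens) for antiproliferative activity, read by MTT assay, with a stated time of 24 h; on this read-out higher numbers stand for weaker inhibition and lower numbers for stronger inhibition. Compound 1 `COc1ccc(-c2cc(C(=O)/C=C/c3cc(OC)c(OC)c(OC)c3)nc3cc(-c4ccccc4)nn23)cc1OC` gives 14700 nM in this assay. Compound 2 `COc1ccc(-c2cc(/C=C/C(=O)c3ccccc3)nc3cc(-c4ccccc4)nn23)cc1OC` gives 10000 nM. Compound 3 `COc1ccc(-c2cc(C(=O)/C=C/c3ccccc3)nc3cc(-c4ccccc4)nn23)cc1OC` gives 15600 nM, the highest of the three numbers, though its step from compound 1, a 1.1-fold higher number from compound 1 to compound 3 (0.03 log units; within the scatter), and its step from compound 2, a 1.6-fold higher number from compound 2 to compound 3 (0.19 log units; within the scatter), both stay within the scatter, so the three cannot be ranked.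

Compound 4 `COc1ccc(-c2cc(C(=O)/C=C/c3ccc(C)cc3)nc3cc(-c4ccccc4)nn23)cc1OC` differs from compound 3 in one place: methyl in place of hydrogen on an aromatic carbon. The step that bears most on this change is the one on the same six-membered aromatic ring of carbon only, a 1.1-fold higher number from compound 1 to compound 3 (0.03 log units; within the scatter), where a much larger change on that ring moved the number by no more than the scatter. The other step, a 1.6-fold higher number from compound 2 to compound 3 (0.19 log units; within the scatter), concerns a different part of the molecule and was likewise small. Within the data shown here, nothing measured so far points to a shift beyond the scatter in this assay for so small an addition, so the expected step, a 1.0-fold lower number from compound 3 to compound 4 (0.02 log units; within the scatter), is essentially none.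

Compound 4 is therefore estimated to give 15000 nM in this assay, with a range from 7000 nM to 32000 nM.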

Compound 4, half-maximal inhibitory concentration: 19500 nM
Compound 4: middle estimate off by 1.3-fold (0.11 log units), on the low side, within the range that was stated.
By their numbers in this assay, from the lowest: compounds 2, 1, 3 and 4 (each within the scatter of the next).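

In this assay, methyl on an aromatic carbon para to a large group gives a small step (a 1.3-fold higher number from compound 3 to compound 4 (0.10 log units; within the scatter)), which shows that this single added carbon, like the larger exchange seen earlier on the same ring, leaves the number within the scatter. Compound 4, with its 4-methylphenyl group, also cannot be separated from the 3,4,5-trimethoxyphenyl compound (a 1.3-fold higher number from compound 1 to compound 4 (0.12 log units; within the scatter)), and its step from the compound with the 2-benzoylethenyl chain (a 2.0-fold higher number from compound 2 to compound 4 (0.29 log units; within the scatter)) likewise stays within the scatter, so all four compounds remain unranked and the ring has not yet been shown to affect the read-out. No independent evidence bears on this result.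

The compounds shown leave open whether a group of a different kind at this ring carbon, such as an amine, a carboxylic acid or a longer alkyl chain, would move the number beyond the scatter. They also leave open whether methyl would give a similarly small step on the phenyl ring of compound 2.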